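Ester-bearing triazole series: trifluoromethyl to fluoro swap on aryl

A few compounds are considered here, and "the series" means these few. Any claim that something is new, unique, unknown or untested is made for them only; others in the source may bear on it.

The series rests on compound 1 `COC(=O)c1nc(C2CCCCC2)n(-c2ccc(F)cc2)n1`, compound 2 `COC(=O)c1nc(C2CCCCC2)n(-c2ccc(C(F)(F)F)cc2)n1` and compound 3 `CCOC(=O)c1nc(-c2ccc[nH]2)n(-c2ccc(C(F)(F)F)cc2)n1`, all assessed in a functional assay on NCI-H226 cells (Homo sapiens) for inhibition, read by MTT assay, with a stated time of 72 h; on this read-out lower numbers stand for stronger inhibition of growth and higher numbers for weaker inhibition of growth. Compound 1 gives 6260 nM, compound 2 gives 5760 nM and compound 3 gives 5610 nM. All three values sit within the usual scatter of one another, so no order among them can be read from this data set.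

Compound 2 and compound 1 differ in one place: fluoro in place of trifluoromethyl on an aromatic carbon. The step recorded for this pair, a 1.1-fold higher number from compound 2 to compound 1 (0.04 log units; within the scatter), is within the scatter. Compound 3 and compound 2 differ in more than one place; the difference between the two cores is not broken down here.

Compound 4 `CCOC(=O)c1nc(-c2ccc[nH]2)n(-c2ccc(F)cc2)n1` has not been measured. It stands to compound 3 as compound 1 stands to compound 2: fluoro in place of trifluoromethyl on an aromatic carbon. The surroundings of the change are described in the same words for both pairs, so the change is the same, made once on each core.

The expectation for compound 4 in this assay rests on one precedent: the step from compound 2 to compound 1, a 1.1-fold higher number from compound 2 to compound 1 (0.04 log units; within the scatter), was within the scatter. The same change on the core of compound 3 is therefore expected to produce a comparably small step, a 1.1-fold higher number from compound 3 to compound 4 (0.03 log units; within the scatter). Compound 4 is estimated at 6000 nM, with a plausible range from 3000 nM to 12000 nM. A single precedent on a different core leaves this estimate loosely anchored.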

Compound 4, concentration for 50% growth inhibition: 5710 nM
Compound 4: middle estimate off by 1.1-fold (0.02 log units), on the high side; the measured number falls inside the stated range.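

In this assay, fluoro in place of trifluoromethyl on an aromatic carbon of compound 3 leaves the growth-inhibition read-out without a change that can be distinguished (a 1.0-fold higher number from compound 3 to compound 4 (0.01 log units; within the scatter)). Set beside the earlier step, the same change gives no difference that can be told apart on the two cores: the same change on two cores in this assay, a 1.1-fold higher number (0.04 log units; within the scatter) from compound 2 to compound 1 and a 1.0-fold higher number (0.01 log units; within the scatter) from compound 3 to compound 4, 1.1-fold (0.03 log units) apart, within the scatter of two such steps. This shows that the swap was silent on both cores in this cell assay, but the agreement is between two steps within the scatter, so it does not show that an effect of measurable size carries from one core to another, nor does it extend to cores beyond these two.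

The compounds shown leave open whether any group in this place can move the read-out, for example an amine or a methoxy group in place of fluoro or trifluoromethyl, and whether replacing the ester with a carboxylic acid or an amide would do so. Also open are the separate contributions of the ester chain and the other group that differ between the two cores, as no pair shown changes either one alone.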